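The source may report more compounds than this note shows. Statements on the series, on what has been measured and on what is new or still open speak of the compounds shown alone.

Values in a functional assay on A549 cells (Homo sapiens) for inhibition, read by sulforhodamine B assay, with a stated time of 48 h; a lower number here means a stronger inhibitor, a higher number a weaker inhibitor:
- compound 1 `COC(=O)[C@@]1(C)C[C@@H](c2coc3ccc(Br)cc3c2=O)N(c2ccccc2)O1`: 9900 nM
- compound 2 `Cc1ccc2occ([C@@H]3[C@H]4C(=O)N(c5ccccc5)C(=O)[C@H]4ON3c3ccccc3)c(=O)c2c1`: > 60000 nM
- compound 3 `COC(=O)[C@@]1(C)C[C@@H](c2coc3ccc(F)cc3c2=O)N(c2ccccc2)O1`: 20300 nM

The entry for compound 2 is a limit, not a number: > 60000 nM. Of the two true numbers in this assay, compound 3 has the higher one, at 20300 nM, and the nearest neighbour is compound 1 at 9900 nM.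

The next change leads to compound 4 `COC(=O)[C@@]1(C)C[C@@H](c2coc3ccc(C)cc3c2=O)N(c2ccccc2)O1`, which has methyl in place of fluoro on an aromatic carbon. The rest of the structure stays the same as in compound 3.

Among the compounds with values here, no measured step has methyl entering at this carbon. Within the data shown here, the only guide is a 2.1-fold higher number from compound 1 to compound 3 (0.31 log units; beyond the scatter), where fluoro replaces bromo on the same aromatic carbon. That step is modest, so a similarly small change is expected here. Its direction is uncertain, with a slight leaning towards a lower number in this assay, since fluoro is leaving and compound 3 holds the higher of the two numbers. The change may well stay within the scatter.

The expected step is a 1.5-fold lower number from compound 3 to compound 4 (0.16 log units; within the scatter). For compound 4 the estimated value is 14000 nM, with an expected range of 6500 nM to 30000 nM.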

Compound 4, half-maximal inhibitory concentration: 700 nM
For compound 4 the middle estimate is 20-fold (1.30 log units) above the measured one; the whole stated range lies above it.
By their numbers in this assay, from the lowest: compound 4; then compound 1; then compound 3. At a limit, above all of these: compound 2.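

In this assay, this aromatic carbon proves far more sensitive than the halogen exchange alone suggested: methyl in place of fluoro gives a 29-fold lower number from compound 3 to compound 4 (1.46 log units; beyond the scatter), and methyl in place of bromo gives a 14-fold lower number from compound 1 to compound 4 (1.15 log units; beyond the scatter). Within the data shown here, both steps are large, whereas the only earlier step at this carbon, a 2.1-fold higher number from compound 1 to compound 3 (0.31 log units; beyond the scatter), is modest, so the choice of group here can move the number much further than swapping one halogen for the other showed. Among the three compounds that differ only at this carbon, the methyl of compound 4 gives the lowest number, and both halogen compounds stand well above it.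

Nothing in the data shown accounts for this gain. Going by these compounds, it remains open whether the gain is particular to methyl or extends to an ethyl group, a longer chain, a methoxy group or an amine on the same aromatic carbon, and whether it persists when the methyl ester of the shared core is replaced by a carboxylic acid.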